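The source may report more compounds than this note shows. Statements on the series, on what has been measured and on what is new or still open speak of the compounds shown alone.

Of the compounds shown here, two of a shared core have been measured. Compound 2 `COCNc1n[n+]([O-])c2ccccc2[n+]1[O-]` carries a short ether-linked side chain on its amine, and in a functional assay on A549 cells (Homo sapiens) for cytotoxicity, read by MTT assay, with a stated time of 72 h (on this read-out higher numbers stand for weaker inhibition and lower numbers for stronger inhibition), compound 2 gives 7450 nM. Compound 1 `COc1ccc2c(c1)[n+]([O-])nc(NCOC(C)c1ccccc1)[n+]2[O-]` differs in several places at once, including an aromatic ring in its side chain, and in this assay compound 1 gives 3130 nM. Of the two numbers, compound 2 stands highest, so it is the weaker of the pair, and the gap to compound 1 lies beyond the usual scatter.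

Compound 3 `[O-][n+]1nc(NCOCc2ccc(Cl)cc2)[n+]([O-])c2ccccc21` is made from compound 2 by one change: 4-chlorophenyl in place of hydrogen on a saturated chain carbon bound to an oxygen on a saturated carbon. The aromatic ring enters where compound 2 has only a hydrogen. Going by the values given here, no measured pair isolates this exact change, so the expectation rests on compound 1, whose side chain also holds an aromatic ring and whose value 3130 nM is lower than that of compound 2. A step of a 2.5-fold lower number from compound 2 to compound 3 (0.40 log units; beyond the scatter) toward a lower number is expected. For compound 3 the estimate is 3000 nM, within a range from 1000 nM to 9000 nM.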

Compound 3, half-maximal inhibitory concentration: 1470 nM
For compound 3 the middle estimate is 2.0-fold (0.31 log units) above the measured one; the measured number falls inside the stated range.
By their numbers in this assay, from the lowest: compound 3; then compound 1; then compound 2.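

Placing 4-chlorophenyl in place of hydrogen on a saturated chain carbon bound to an oxygen on a saturated carbon gives, in this assay, a 5.1-fold lower number from compound 2 to compound 3 (0.70 log units; beyond the scatter) on the shared core. Going by these compounds alone, this is the first pair here that differs in one place only, so the change in number can be tied to this single swap, which the comparison with compound 1 could not do. It shows that this position accepts a group as large as 4-chlorophenyl while the number falls rather than rises.

The compounds shown leave open whether the chlorine or the ring itself carries the step, and how a plain phenyl, a pyridine ring or a longer chain would compare at this position. No measured evidence on hand accounts for the size of this step.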